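The source may report more compounds than this note shows. Statements on the series, on what has been measured and on what is new or still open speak of the compounds shown alone.

Compounds measured so far:
- compound 1, `COc1ccc(C(=O)NCCNc2nc3cc(C)cc(C)c3cc2C#N)c(OC)c1`: 4200 nM
- compound 2, `COc1ccc(C(=O)NCCNc2nc3cc(C)cc(C)c3cc2C#N)nc1`: 2700 nM

For the measured compounds named here, compound 2 has the lowest of the two numbers in an in vitro assay on FRT cells with Cystic fibrosis transmembrane conductance regulator variant F508del (Homo sapiens) as the target, read by fluorescence, with a stated time of 24 h, at 37 degrees C, in the presence of a further agent that is not named here (a lower number here means that less compound is needed, a higher number that more compound is needed for the effect), but the only measured step, a 1.6-fold lower number from compound 1 to compound 2 (0.19 log units; within the scatter), is within the scatter, so compound 2 and compound 1 cannot be separated on these data.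

Compound 3, `COc1cccc(OC)c1C(=O)NCCNc1nc2cc(C)cc(C)c2cc1C#N`, returns to a dimethoxyphenyl on the amide: 2,6-dimethoxyphenyl in place of 5-methoxypyridin-2-yl on a carbonyl carbon. Going by the values given here, this step is the reverse of the one measured, with a different pattern of the two methoxy groups, and no measured step tells how the pattern matters. A number close to compound 1 is therefore expected, with the step of a 1.7-fold higher number from compound 2 to compound 3 (0.22 log units; within the scatter) probably within the scatter.

Compound 3 is estimated at 4500 nM, range 1500 nM to 13000 nM.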

Compound 3, half-maximal effective concentration: 3700 nM
For compound 3 the middle estimate is 1.2-fold (0.09 log units) above the measured one; the measured number falls inside the stated range.
By their numbers in this assay, from the lowest: compounds 2, 3 and 1 (each within the scatter of the next).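

In this assay the new compound gives a 1.4-fold higher number from compound 2 to compound 3 (0.14 log units; within the scatter) and a 1.1-fold lower number from compound 1 to compound 3 (0.06 log units; within the scatter) so 2,6-dimethoxyphenyl on this carbonyl carbon cannot be separated from either 5-methoxypyridin-2-yl or 2,4-dimethoxyphenyl. Changing the pattern of the two methoxy groups on the phenyl ring therefore produces no readable difference here. No supporting data are available to explain this result.

Going by these compounds, whether any group at this position can move the number beyond the scatter remains open. A carboxylic acid or an aliphatic amine in place of the aromatic ring would test this.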